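This account rests on a few compounds, and the source may have more. Where it says the series, first, only, none or still open, it means among the compounds named here.

Working notes on the series, followed in an ADME assay on the whole organism (Rattus norvegicus) for pharmacokinetics; a lower number here means slower removal, a higher number faster removal of the compound. Compound 1 `O=C(C1=C(O)C(=O)N(c2ccc(-c3ccon3)cc2)C1C1CCCCC1)c1ccc(CO)cc1` gives 3.8 mL/min/kg in this assay. Compound 2 `CCC(CC)C1C(C(=O)c2ccc(OC)cc2)=C(O)C(=O)N1c1ccc(-c2ccon2)cc1` gives 5.1 mL/min/kg in this assay. The numbers of compound 2 and compound 1 lie within the scatter of each other, so the two stand together and no order can be read between them; both are removed slowly. Among the compounds with values here, no step between measured compounds that differ in one place is available. Compound 2 and compound 1 differ in more than one place.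

Compound 3 `COc1ccc(C(=O)C2=C(O)C(=O)N(c3ccc(-c4ccon4)cc3)C2c2ccccc2OC)cc1` is not yet measured. It differs from compound 2 by 2-methoxyphenyl in place of pentan-3-yl on a saturated ring carbon. Nothing in the measured pair speaks to this exchange on its own. The expectation for compound 3 in this assay is therefore a step from compound 2 no larger than the scatter, in no fixed direction, with a wide allowance for either way.

Compound 3 is expected at 5.5 mL/min/kg, in the range 2.2 mL/min/kg to 14 mL/min/kg. That estimate means an expected step of a 1.1-fold higher number from compound 2 to compound 3 (0.03 log units; within the scatter).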

Compound 3, clearance: 8.8 mL/min/kg
Estimate against measurement, compound 3: 1.6-fold (0.20 log units) below; measured number inside the range.
By their numbers in this assay, from the lowest: compounds 1, 2 and 3 (each within the scatter of the next, the first and the last beyond it).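

In this assay, within the data shown here, 2-methoxyphenyl in place of pentan-3-yl on the saturated ring carbon next to the ring nitrogen gives a 1.7-fold higher number from compound 2 to compound 3 (0.24 log units; within the scatter) and provides the first step that differs in one place. At this position, a group bearing a six-membered aromatic ring and an open branched chain with no ring therefore stand together, so the read-out does not separate these two groups. The new hydrogen-bond acceptor and the larger heavy-atom count of 2-methoxyphenyl come with no step beyond the scatter, and nothing measured on hand gives a reason for this.

Among these compounds, the single step covers only these two groups, so it remains open whether a group of another kind on this carbon, such as an aminomethyl group or a carboxylic acid, would stand with them or move the clearance beyond the scatter. As far as these compounds go, it also remains open whether the same exchange would read alike with the (4-methoxyphenyl)carbonyl group replaced, or with the 4-(1,2-oxazol-3-yl)phenyl group replaced by another substituent on the ring nitrogen.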